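The source may hold more compounds than are shown below. What is called first, only, known or untested is meant among the compounds shown, and "the series" means these compounds.

Measured in a functional assay on HL-60 cells (Homo sapiens) for cytotoxicity, read by WST assay, with a stated time of 48 h; on this read-out lower numbers stand for an effect already at smaller amounts and higher numbers for an effect only at larger amounts of compound:
Compound 1 `Oc1ccccc1C[C@H]1COC[C@@H]1Cc1ccc(Cl)c(Cl)c1`: 34000 nM
Compound 2 `CCCCOc1ccccc1C[C@H]1COC[C@@H]1Cc1ccc(Cl)c(Cl)c1`: 20000 nM

Compound 2 lies within the scatter of compound 1, so neither stands apart on these two numbers. Compound 3 `Cc1ccccc1C[C@H]1COC[C@@H]1Cc1ccc(Cl)c(Cl)c1` has methyl in place of butoxy on an aromatic carbon, ortho to a large group: methyl in place of butoxy on an aromatic carbon. Going by the values given here, the only measured step at this place, butyl in place of hydrogen on an oxygen on an aromatic ring, is a 1.7-fold lower number from compound 1 to compound 2 (0.23 log units; within the scatter). No step beyond the scatter is therefore expected in this assay, and no direction can be given. Compound 3 is estimated at 25000 nM, with an expected range from 10000 nM to 60000 nM. The estimated change is a 1.3-fold higher number from compound 2 to compound 3 (0.10 log units; within the scatter).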

Compound 3, half-maximal effective concentration: 21000 nM
For compound 3 the middle estimate is 1.2-fold (0.08 log units) above the measured one, within the range that was stated.
By their numbers in this assay, from the lowest: compounds 2, 3 and 1 (each within the scatter of the next).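

In this assay, this place on the aromatic ring has now carried hydroxy, butoxy and methyl, and the new steps read a 1.1-fold higher number from compound 2 to compound 3 (0.02 log units; within the scatter) and a 1.6-fold lower number from compound 1 to compound 3 (0.21 log units; within the scatter). Methyl thus takes away the oxygen at this place with no step beyond the scatter, whereas the earlier pair varied only what sits on that oxygen. No evidence is at hand that bears on this result.

On these data alone, whether an amine, a carboxylic acid or a longer chain at this place would give a step beyond the scatter remains open.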